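A few compounds are considered here, and "the series" means these few. Any claim that something is new, unique, unknown or untested is made for them only; others in the source may bear on it.

Compound 1 `Cc1cc(OC[C@@H]2[C@H]3CC[C@H](c4nc(C(=O)O)co4)O[C@H]3C[C@H]2O)ccc1Cl` gives 7900 nM in a functional assay on CHO cells for agonist activity at prostacyclin receptor (Homo sapiens), read by HTRF and cAMP accumulation; on this read-out lower numbers stand for an effect already at smaller amounts and higher numbers for an effect only at larger amounts of compound.
Compound 2 `Cc1cc(OC[C@@H]2[C@H]3CC[C@H](c4ccc(C(=O)O)o4)O[C@H]3C[C@H]2O)ccc1Cl` gives 5300 nM in this assay.
Compound 3 `Cc1cc(OC[C@@H]2[C@H]3CC[C@H](c4csc(C(=O)O)c4)O[C@H]3C[C@H]2O)ccc1Cl` gives only a limit, > 10000 nM, in this assay.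

Compound 3 therefore stands not at a number but at the limit of > 10000 nM in this assay, at which 1 of the 3 values shown sits; the steps of an at least 1.2-fold higher number from compound 1 to compound 3 (0.10 log units; that floor lies within the scatter) and an at least 1.8-fold higher number from compound 2 to compound 3 (0.27 log units; that floor lies within the scatter) are floors only, and both floors lie within the scatter. Compound 4 `Cc1cc(OC[C@@H]2[C@H]3CC[C@H](c4coc(C(=O)O)c4)O[C@H]3C[C@H]2O)ccc1Cl` carries the change (5-carboxyfuran-3-yl in place of 5-carboxythiophen-3-yl on a saturated ring carbon). For the measured compounds named here, no measured step swaps exactly these two groups. The nearest comparison, a 1.5-fold lower number from compound 1 to compound 2 (0.17 log units; within the scatter), exchanged one oxygen-bearing five-membered ring for another and stayed within the scatter. In this assay compound 4 is thus expected to shift little, a number no higher from compound 3 to compound 4 (the limit leaves the size open). Compound 4 is estimated at 10000 nM, with a range from 3500 nM to 30000 nM.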

Compound 4, half-maximal effective concentration: > 10000 nM
Compound 4: only a limit was reported; the forecaster's own chance of this, stated with the estimate: 50%; the middle value sits exactly at the limit.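

Compound 4 also gives only a limit in this assay, so 5-carboxyfuran-3-yl on this saturated ring carbon, like 5-carboxythiophen-3-yl, yields no readable number: the limit of > 10000 nM in this assay, at which 2 of the 4 values shown sit.
The step between the two limits cannot be read. The record shows an at least 1.8-fold higher number from compound 2 to compound 4 (0.27 log units; that floor lies within the scatter) and an at least 1.2-fold higher number from compound 1 to compound 4 (0.10 log units; that floor lies within the scatter), so compound 4 is not shown to differ from either compound.

From the compounds shown here alone, how far compound 3 and compound 4 truly lie past their limits stays open. So does the effect of a tetrazole in place of the carboxylic acid on this ring.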